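Amide substituents on a shared core in SW480 cytotoxicity

The source may hold more compounds than are shown below. What is called first, only, known or untested is meant among the compounds shown, and "the series" means these compounds.

Compound 1 `C=CC1=C(C(=O)NCCC)C(c2ccc(F)cc2)OC1`: > 100000 nM
Compound 2 `C=CC1=C(C(=O)NCc2ccc(Cl)cc2)C(c2ccc(F)cc2)OC1`: > 100000 nM
Compound 3 `C=CC1=C(C(=O)NC2CCCCC2)C(c2ccc(F)cc2)OC1`: > 100000 nM

Three amides on one core have been measured in a functional assay on SW480 cells (Homo sapiens) for cytotoxicity, read by MTT assay, with a stated time of 24 h; a lower number here means a stronger inhibitor, a higher number a weaker inhibitor. Compound 1 carries a propyl on the amide nitrogen and gives only a limit, > 100000 nM. Compound 2 carries a 4-chlorobenzyl and likewise gives only a limit, > 100000 nM. Compound 3 carries a cyclohexyl and again gives only a limit, > 100000 nM. Because all three values sit at the limit of > 100000 nM in this assay, at which 3 of the 3 values shown sit, none of the steps between them can be sized: a step that the two limits leave unreadable from compound 1 to compound 2, a step that the two limits leave unreadable from compound 1 to compound 3 and a step that the two limits leave unreadable from compound 2 to compound 3 are all unreadable. Compound 3 therefore stands nowhere in particular; it shares a ceiling with the other two.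

Compound 4 `C=CC1=C(C(=O)Nc2cccc(C)c2)C(c2ccc(F)cc2)OC1` differs from compound 3 by 3-methylphenyl in place of cyclohexyl on an amide-type nitrogen. Every measured step bears on this one only in the weakest sense: each exchanged the group on the amide nitrogen, and each left the value at the limit. Among the compounds with values here, nothing in these data points to a change in this assay beyond the scatter, so compound 4 is expected to behave like compound 3, with a step that the limit leaves unreadable from compound 3 to compound 4 expected to be no real step. The estimate for compound 4 is 150000 nM, within 30000 nM to 1000000 nM, most likely reported again as a limit.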

Compound 4, half-maximal inhibitory concentration: > 100000 nM
Compound 4: a limit, no number; the forecaster's own chance of this, stated with the estimate: 80%; the middle value is on the limit's open side.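

In this assay compound 4 gives > 100000 nM as a limit and not a number, so its steps from compound 1, compound 2 and compound 3 cannot be read. The compounds shown leave open whether any group on the amide nitrogen of the shared core gives a measurable value in this assay at all.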